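From compound 2 to compound 3: a toxicity limit

This account rests on a few compounds, and the source may have more. Where it says the series, first, only, none or still open, it means among the compounds named here.

Measured in a toxicity assay on THP-1 cells (Homo sapiens) for inhibition; on this read-out lower numbers stand for higher toxicity in this test and higher numbers for lower toxicity in this test:
Compound 1 `COc1ccc(-c2cnc(NC(=O)c3ccccc3F)n2C)cc1`: > 100000 nM
Compound 2 `COc1ccc(-c2cnc(NC(=O)c3ccccn3)n2C)cc1`: > 100000 nM

In this assay, compound 2 gives > 100000 nM, which is a limit and not a number. Among the measured compounds shown here, the only measured step is a step that the two limits leave unreadable from compound 1 to compound 2, so it has no size to carry forward. The one firm observation is the limit of > 100000 nM in this assay, at which 2 of the 2 values shown sit.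

Compound 3 `COc1ccc(-c2cnc(NC(=O)c3ccc(Cl)cc3)n2C)cc1` keeps the shared core and changes a single group: 4-chlorophenyl in place of pyridin-2-yl on a carbonyl carbon. Neither compound 1 nor compound 2 gave a number, so the data offer only weak guidance. The most reasonable expectation is no step beyond the scatter, with compound 3 likely to remain at the limit, though a small move toward higher toxicity is possible. The expected change is a number no higher from compound 2 to compound 3 (the limit leaves the size open). For compound 3 the estimated value is 100000 nM, with an expected range of 40000 nM to 150000 nM.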

Compound 3, half-maximal cytotoxic concentration: > 100000 nM
Compound 3 gave a limit, no number (the forecaster's own chance of this, stated with the estimate: 70%); the middle value lies on the limit itself.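

Compound 1, compound 2 and compound 3 give only limits, not numbers, in this assay, so the steps among them cannot be read: the limit of > 100000 nM in this assay, at which 3 of the 3 values shown sit. The compounds shown leave open whether any group on this carbonyl carbon changes toxicity in this assay, and by how much.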